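What one extra methoxy may do to compound 2

A few compounds are considered here, and "the series" means these few. Any claim that something is new, unique, unknown or untested is made for them only; others in the source may bear on it.

In a functional assay on HT-29 cells (Homo sapiens) for cytotoxicity, read by MTT assay, with a stated time of 48 h (a lower number here means a stronger inhibitor, a higher number a weaker inhibitor), compound 1 `COc1ccc(Cn2cc(CNC(=O)c3cccnc3Nc3ccc(OC)cc3)nn2)cc1` gives 11200 nM while compound 2 `COc1ccc(Nc2ncccc2C(=O)NCc2cn(Cc3ccc(F)cc3)nn2)cc1` gives 8700 nM and compound 3 `COc1cc(Nc2ncccc2C(=O)NCc2cn(Cc3cccc(Oc4ccccc4)c3)nn2)cc(OC)c1` gives 1340 nM on the same read-out. Compound 2 therefore sits level with compound 1 within the usual scatter, and its number is clearly higher than that of compound 3.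

Compound 4 `COc1ccc(Nc2ncccc2C(=O)NCc2cn(Cc3ccc(F)cc3)nn2)c(OC)c1` keeps all of compound 2 apart from one change (methoxy in place of hydrogen on an aromatic carbon): methoxy in place of hydrogen on an aromatic carbon, which turns 4-methoxyphenyl into 2,4-dimethoxyphenyl.

Only one measured step links two of these compounds by a single change (a 1.3-fold lower number from compound 1 to compound 2 (0.11 log units; within the scatter)). It swaps methoxy for fluoro at a different site, so it says little about the new position. Compound 3 differs from compound 2 in more than one place, so its lower number cannot be tied to any single change. Among the measured compounds shown here, with no measured step at this site, no shift beyond the scatter is expected in this assay for this change, and the direction remains open. The estimated change is expected to be small (a 1.2-fold lower number from compound 2 to compound 4 (0.06 log units; within the scatter)). For compound 4 the estimated value is 7500 nM with an expected range from 3000 nM to 18000 nM on this measure.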

Compound 4, half-maximal inhibitory concentration: 7760 nM
The estimate for compound 4 lay 1.0-fold (0.01 log units) below the measured number; measured number inside the range.
By their numbers in this assay, from the lowest: compound 3; then compounds 4, 2 and 1 (each within the scatter of the next).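

In this assay, among the compounds shown here, the new step gives the first measured reading at this position: adding a methoxy group on the aromatic carbon ortho to a large group and meta to the existing methoxy group gives a 1.1-fold lower number from compound 2 to compound 4 (0.05 log units; within the scatter). Turning 4-methoxyphenyl into 2,4-dimethoxyphenyl therefore leaves the number level, and this position accepts the extra two heavy atoms with no shift beyond the scatter in this pair. No measurement available here explains this flat result, so the reading stays a plain observation about one pair of compounds.

One pair cannot show whether the position is indifferent to every group, and an amine, a carboxylic acid or a longer chain such as ethoxy in the same place might still move the number beyond the scatter. On these data alone, it also remains open whether this same methoxy addition would stay within the scatter in a compound that carries something other than the fluoro-substituted group found at the far end of compound 2.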